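Stilbene sulfonamides: hydroxy for fluoro on the distal ring

The compounds below may be only part of what the source reports. "The series", "measured", "known", "first", "only" and "open" are said of these compounds alone.

Of the compounds shown here, two have been measured. In a functional assay on NCI-H226 cells (Homo sapiens) for inhibition (a higher number here means a weaker inhibitor of growth, a lower number a stronger inhibitor of growth), compound 1 `COc1cc(/C=C/c2ccc(S(N)(=O)=O)cc2)cc(OC)c1` gives 12300 nM and compound 2 `NS(=O)(=O)c1ccc(/C=C/c2ccc(F)cc2)cc1` gives 7970 nM; the two values lie within the scatter of each other, so no order can be read from them. Compound 3 `NS(=O)(=O)c1ccc(/C=C/c2ccc(O)cc2)cc1` is not yet measured. It differs from compound 2 by hydroxy in place of fluoro on an aromatic carbon. Among the measured compounds shown here, no measured pair shows this change, so there is no step to lean on; the expectation is a step of a 1.1-fold higher number from compound 2 to compound 3 (0.05 log units; within the scatter) that does not go beyond the scatter. Compound 3 is thus expected to give about 9000 nM, within 3000 nM to 27000 nM.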

Compound 3, concentration for 50% growth inhibition: 11100 nM
For compound 3 the middle estimate is 1.2-fold (0.09 log units) below the measured one; the measured number falls inside the stated range.
By their numbers in this assay, from the lowest: compounds 2, 3 and 1 (each within the scatter of the next).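

With hydroxy in place of fluoro on an aromatic carbon, para to a large group, this assay shows a 1.4-fold higher number from compound 2 to compound 3 (0.14 log units; within the scatter). Among the compounds shown here, this is the first single-place change readable, and at this position, the entry of one hydrogen-bond donor and one hydrogen-bond acceptor leaves the number within the scatter. No measurement bears on the reason for this result.

As far as these compounds go, whether an amine or a carboxylic acid at this position would give a step beyond the scatter remains open. Also open, from the compounds shown here alone, is whether the same exchange behaves alike on another core.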